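The source may report more compounds than this note shows. Statements on the series, on what has been measured and on what is new or still open speak of the compounds shown alone.

Notes on the series in a functional assay on IGROV-1 cells (Homo sapiens) for cytotoxicity, read by sulforhodamine B assay, with a stated time of 48 h, tested at 0.1 uM; on this read-out higher numbers stand for a weaker effect at the one concentration tested and lower numbers for a stronger effect. Compound 3 `COc1ccc(-c2cc(/C=C/C(=O)c3ccc(N)cc3)[nH]n2)cc1OC` gives 106%. Compound 1 `COc1cc(-c2cc(/C=C/C(=O)c3ccc(N)cc3)[nH]n2)cc(OC)c1OC` differs from compound 3 by methoxy in place of hydrogen on an aromatic carbon; in this assay compound 1 gives 108%, and the step of a number 2 percentage points higher from compound 3 to compound 1 (within the scatter) stays within the scatter. Compound 2 `COc1ccc(C(=O)/C=C/c2cc(-c3cc(OC)c(OC)c(OC)c3)n[nH]2)cc1OC` is built on a different core; the difference between the cores of compound 2 and compound 3 is not broken down here. In this assay, among the compounds with values here, compound 2 gives 96%, and the step of a number 12 percentage points lower from compound 1 to compound 2 (beyond the scatter) is the only one among the measured pairs that reaches beyond the scatter. Compound 4 `COc1cc(C(=O)/C=C/c2cc(-c3cc(OC)c(OC)c(OC)c3)n[nH]2)cc(OC)c1OC` has not yet been measured. It differs from compound 2 by methoxy in place of hydrogen on an aromatic carbon, the same change as from compound 3 to compound 1, with the place described in the same words. The earlier step of a number 2 percentage points higher from compound 3 to compound 1 (within the scatter) was within the scatter. On that basis the step that is expected is similarly small: a number 2 percentage points higher from compound 2 to compound 4 (within the scatter). Compound 4 is therefore estimated at 98%, with a likely range from 87% to 109%.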

Compound 4, a percentage reported as activity, at one concentration (the size of the read-out at that concentration, not a potency): 103%
Compound 4: the middle estimate sits 5 percentage points below what was measured; measured number inside the range.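

The new step, for methoxy in place of hydrogen on an aromatic carbon, is a number 7 percentage points higher from compound 2 to compound 4 (within the scatter). Set beside the earlier step in this assay, it shows that the change carries from one core to the other with no difference that can be told from the scatter: the same change on two cores in this assay, a number 2 percentage points higher (within the scatter) from compound 3 to compound 1 and a number 7 percentage points higher (within the scatter) from compound 2 to compound 4, 5 percentage points apart, within the scatter of two such steps This agreement holds only for these two cores at the single concentration tested, and with both steps within the scatter, it shows that the change stays small on both cores, not that a measurable effect of the change transfers between them.

The compounds shown leave open whether a different group on that aromatic carbon, such as a carboxylic acid or a longer chain like butoxy, would give a step beyond the scatter on either core. Also open, as far as these compounds go, is whether methoxy in place of hydrogen stays this small on these cores at other concentrations.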